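Series notes: chalcone methoxyphenyl ketones, one-concentration cell read-out

A few compounds are considered here, and "the series" means these few. Any claim that something is new, unique, unknown or untested is made for them only; others in the source may bear on it.

Measured so far in a functional assay on Huh-7 cells (Homo sapiens), read by fluorescence and BrdU incorporation, with a stated time of 48 h, tested at 10 uM; on this read-out higher numbers stand for a weaker effect at the one concentration tested and lower numbers for a stronger effect:
compound 1, `COc1cc(OC)c(C(=O)/C=C/c2ccc(Cl)cc2)c(OC)c1`, gives 33%
compound 2, `COc1cccc(/C=C/C(=O)c2c(O)cc(OC)cc2OC)c1`, gives 56%
compound 3, `COc1cc(O)c(C(=O)/C=C/c2ccccc2SC)c(OC)c1`, gives 50%

Compound 1 has the lowest number of the three, which on this read-out means the strongest effect at the one concentration tested. Its nearest neighbour is compound 3, whose number is higher by an amount beyond the scatter; the furthest is compound 2, also higher by more than the scatter. For the measured compounds named here, no two of the three differ in only one place, so no single-change step can be drawn among them.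

Compound 4, `COc1cc(OC)c(C(=O)/C=C/c2ccc(F)cc2)c(OC)c1`, is yet to be measured. It differs from compound 1 as follows: fluoro in place of chloro on an aromatic carbon. With no measured step of this kind in the series, the size of the change is an open question; the expectation is a small step upward in this assay, likely near the edge of the scatter, so that the step from compound 1 to compound 4 is estimated at a number 12 percentage points higher from compound 1 to compound 4 (beyond the scatter). Compound 4 is expected to give about 45%, within a range of 30% to 65%.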

Compound 4, a percentage reported as activity, at one concentration (the size of the read-out at that concentration, not a potency): 44%
Beside the measured number, compound 4's estimate is 1 percentage points above it; low and high end bracket the measured number.
By their numbers in this assay, from the lowest: compound 1; then compounds 4, 3 and 2 (each within the scatter of the next, the first and the last beyond it).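

For the compounds shown here, the 4-chlorophenyl to 4-fluorophenyl change provides the first single-change step: in this assay the result is a number 11 percentage points higher from compound 1 to compound 4 (beyond the scatter) and the effect at the one concentration tested is therefore weaker. This aromatic carbon is thus not indifferent to which of these two halogens it carries, and within this pair the chloro group goes with the stronger effect. Nothing measured here accounts for the step.

On these data alone, how an amine or a carboxylic acid on this aromatic carbon would read remains open, since the comparison covers only chloro and fluoro. Also open, as far as these compounds go, is whether the same change would give a step of similar size on the cores of compound 2 and compound 3, or how it would read as a potency across several concentrations.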